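A few compounds are considered here, and "the series" means these few. Any claim that something is new, unique, unknown or untested is made for them only; others in the source may bear on it.

Measured compounds in a physicochemical assay for solubility, with a stated time of 18 h, at pH 7.4; a higher number here means a more soluble compound, a lower number a less soluble compound:
- compound 1 `COc1ccc(Oc2ccc3c(NCCCNCc4cc(F)ccc4OC)ccnc3c2)cc1` gives 14500 nM
- compound 2 `COc1ccc(F)cc1CNCCCNc1ccnc2cc(Oc3ccc(F)cc3)ccc12` gives 14500 nM
- compound 3 `COc1ccc(F)cc1CNCCCNc1ccnc2cc(Cc3ccc(F)cc3Cl)ccc12` gives 4200 nM

Compound 3 holds the lowest number of the three. Its nearest neighbour is compound 1, and the gap is a 3.5-fold lower number from compound 1 to compound 3 (0.54 log units; beyond the scatter); the gap to compound 2 is the same size, a 3.5-fold lower number from compound 2 to compound 3 (0.54 log units; beyond the scatter). Compounds 1 and 2 sit within the scatter of each other, the step between them being no change at the digits printed from compound 1 to compound 2 (within the scatter).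

Compound 4 `COc1ccc(F)cc1CNCCCNc1ccnc2cc(Oc3cccc(N(C)C)c3)ccc12` is not yet measured in this assay. Its difference from compound 3 is 3-(dimethylamino)phenoxy in place of 2-chloro-4-fluorobenzyl on an aromatic carbon. The two measured steps that bear on it are the ones that run the other way, from an aryloxy group to the benzyl group at the same position: a 3.5-fold lower number from compound 1 to compound 3 (0.54 log units; beyond the scatter) and a 3.5-fold lower number from compound 2 to compound 3 (0.54 log units; beyond the scatter). Both were modest and both lowered the number. Returning to an aryloxy group is therefore expected to raise the number in this assay by a step of similar, modest size, though the dimethylamino substituent has no measured counterpart here, so the width is kept broad.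

The estimated step from compound 3 is a 3.3-fold higher number from compound 3 to compound 4 (0.52 log units; beyond the scatter). For compound 4 the expected value in this assay is 14000 nM, with a range from 6000 nM to 32000 nM.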

Compound 4, solubility: 14500 nM
Compound 4: the middle estimate sits 1.0-fold (0.02 log units) below what was measured; measured number inside the range.
By their numbers in this assay, from the lowest: compound 3; then compounds 1, 2 and 4 (each within the scatter of the next).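

In this assay, a third aryloxy group on this aromatic carbon, 3-(dimethylamino)phenoxy, stands clear of the 2-chloro-4-fluorobenzyl group, with a 3.5-fold higher number from compound 3 to compound 4 (0.54 log units; beyond the scatter), so the gap seen with the two earlier aryloxy groups now holds for three, with no listed aryloxy compound going against it. The group on the oxygen can also differ in both its substituent and where that substituent sits without moving the read-out: the steps are no change at the digits printed from compound 2 to compound 4 (within the scatter) and no change at the digits printed from compound 1 to compound 4 (within the scatter), leaving 3-(dimethylamino)phenyl, 4-fluorophenyl and 4-methoxyphenyl unseparated here. No accompanying measurement accounts for these numbers.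

Among the compounds shown here, only one benzyl group stands in the set, so the lower number of compound 3 cannot yet be assigned to the carbon link or to the chlorine and fluorine on its ring, and an unsubstituted benzyl group would help to separate them. Also open, as far as these compounds go, is whether a phenoxy group carrying a carboxylic acid or a morpholine would stay level with compounds 1, 2 and 4.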